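A few compounds are considered here, and "the series" means these few. Any claim that something is new, unique, unknown or untested is made for them only; others in the source may bear on it.

Measured in a functional assay (strain AB) with Danio rerio as the target, read by microscopy, with a stated time of 1 h; a higher number here means that more compound is needed for the effect, a lower number that less compound is needed:
- Compound 1 `CCC1CCc2c(sc(NC(=O)Nc3ccc(Cl)cc3)c2C(N)=O)C1`: > 25000 nM (a limit)
- Compound 2 `CC(C)(C)OC(=O)CCC[N+]1(C)CCc2c(sc(NC(=O)Nc3ccc(Cl)cc3)c2C(N)=O)C1`: 250 nM

Among the measured compounds shown here, compound 2 holds the only actual number in this small set, since the other entry is a limit rather than a measurement. Compound 3 `C[N+]1(CC2CCC2)CCc2c(sc(NC(=O)Nc3ccc(Cl)cc3)c2C(N)=O)C1` has not yet been measured. It keeps the core of compound 2 and changes one group: cyclobutyl in place of 2-(tert-butoxycarbonyl)ethyl on a saturated chain carbon bound to an amine nitrogen in a ring. In words, cyclobutyl stands in place of 2-(tert-butoxycarbonyl)ethyl on a saturated chain carbon bound to an amine nitrogen in a ring.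

For the measured compounds named here, no measured pair differs in just one place, so the size of this change can only be judged loosely. A moderate move towards needing more compound seems likely, though with wide uncertainty. The expected change is a 4.0-fold higher number from compound 2 to compound 3 (0.60 log units; beyond the scatter). For compound 3 the estimated value is 1000 nM, within an expected range of 150 nM to 8000 nM.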

Compound 3, half-maximal effective concentration: 210 nM
Compound 3: the middle estimate sits 4.8-fold (0.68 log units) above what was measured; the measured number falls inside the stated range.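

In this assay, putting cyclobutyl in place of 2-(tert-butoxycarbonyl)ethyl leaves the number within the usual scatter (a 1.2-fold lower number from compound 2 to compound 3 (0.08 log units; within the scatter)). Compound 2 alone could not show whether its value depended on the tert-butoxycarbonyl part, and compound 3 shows that a value of this size does not require it. At this position on the saturated chain carbon bound to an amine nitrogen in a ring, a small all-carbon ring without hydrogen-bond acceptors therefore does as well in this assay as the larger oxygen-bearing group.

On these data alone, two groups cannot show how much variety this position accepts, so it remains open whether a carboxylic acid, an amine or a longer chain would give a similar number. No measured property shown here accounts for the match between these two groups.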